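Moving a Fluorine Around a Phenyl Ring on the Triazole

This account rests on a few compounds, and the source may have more. Where it says the series, first, only, none or still open, it means among the compounds named here.

Measured so far:
- Compound 1 `CCCCCCc1cn(C(c2ccccc2)c2cc3cc(Br)ccc3nc2OC)nn1`: 2.32%
- Compound 2 `COc1nc2ccc(Br)cc2cc1C(c1ccccc1)n1cc(-c2cccc(F)c2)nn1`: 14.6%

In an ADME assay on PC-3 cells (Homo sapiens) for cytotoxicity, read by sulforhodamine B assay, with a stated time of 48 h, tested at 10 uM (a higher number here means more inhibition at the concentration tested (going by the name of the read-out), a lower number less inhibition), compound 2 gives the higher of the two numbers, a number 12.3 percentage points higher from compound 1 to compound 2 (beyond the scatter). Compound 3 `COc1nc2ccc(Br)cc2cc1C(c1ccccc1)n1cc(-c2ccc(F)cc2)nn1` is not yet measured; its difference from compound 2 is 4-fluorophenyl in place of 3-fluorophenyl on an aromatic carbon. Within the data shown here, the only measured step exchanges hexyl for 3-fluorophenyl on an aromatic carbon, which is a different kind of change from shifting a fluorine within the same ring, so it offers no direct guide to the size of this step. Among the measured compounds shown here, with no comparable precedent among the two measured compounds, the step is expected to stay within the usual scatter, in either direction. Compound 3 is therefore estimated to give 13% in this assay, within a range of 0% to 30%, an expected step of a number 1.6 percentage points lower from compound 2 to compound 3 (within the scatter).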

Compound 3, a percentage reported as inhibition, at one concentration (the size of the read-out at that concentration, not a potency): 16.4%
Beside the measured number, compound 3's estimate is 3.4 percentage points below it, and the stated range covers the measured number.
By their numbers in this assay, from the lowest: compound 1; then compounds 2 and 3 (each within the scatter of the next).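

In this assay, moving the fluorine around the ring gives a number 1.8 percentage points higher from compound 2 to compound 3 (within the scatter), so the 4-fluorophenyl and 3-fluorophenyl groups cannot be told apart on this aromatic carbon. Replacing hexyl with 4-fluorophenyl gives a number 14.1 percentage points higher from compound 1 to compound 3 (beyond the scatter), which means that both fluorophenyl compounds stand clear of the hexyl compound, though by a modest margin. No measurement shown here explains this pattern.

The compounds shown leave open whether the fluorine matters at all, as a plain phenyl group would be needed to test that against compound 3. They also leave open how an amine or a carboxylic acid on that phenyl ring would read in this assay.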